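Swapping the arylidene group in a semicarbazone series

The compounds below may be only part of what the source reports. "The series", "measured", "known", "first", "only" and "open" are said of these compounds alone.

Compound 1 `COc1cc2c(Oc3ccc(NC(=O)N/N=C/c4ccc(C(F)(F)F)cc4)cc3F)ccnc2cc1OCCCN1CCCCC1`: 1100 nM
Compound 2 `COc1cc2c(Oc3ccc(NC(=O)N/N=C/c4ccc(Cl)cc4Cl)cc3F)ccnc2cc1OCCCN1CCCCC1`: 750 nM
Compound 3 `COc1cc2c(Oc3ccc(NC(=O)N/N=C/c4ccc(N(C)C)cc4)cc3F)ccnc2cc1OCCCN1CCCCC1`: 1400 nM

Three compounds sharing one core and differing only in the aryl group on the carbon double-bonded to nitrogen have been tested in a functional assay on MDA-MB-231 cells (Homo sapiens) for cytotoxicity, read by MTT assay, with a stated time of 72 h; a lower number here means a stronger inhibitor, a higher number a weaker inhibitor. Compound 1 gives 1100 nM, compound 2 gives 750 nM and compound 3 gives 1400 nM. Compound 3 sits within the usual scatter of both neighbours: the step from compound 1 to compound 3 is a 1.3-fold higher number from compound 1 to compound 3 (0.10 log units; within the scatter), and that from compound 2 to compound 3 is a 1.9-fold higher number from compound 2 to compound 3 (0.27 log units; within the scatter). Likewise, a 1.5-fold lower number from compound 1 to compound 2 (0.17 log units; within the scatter) separates compound 1 from compound 2. So far, no exchange of the aryl group has moved this assay beyond its scatter.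

Compound 4 `C=CCc1cccc(/C=N/NC(=O)Nc2ccc(Oc3ccnc4cc(OCCCN5CCCCC5)c(OC)cc34)c(F)c2)c1OC` continues the same kind of exchange: 3-allyl-2-methoxyphenyl in place of 4-(dimethylamino)phenyl on a carbon with a double bond to nitrogen. All three measured steps bear on it, as each also replaces this aryl group, and each stayed within the scatter. Compound 4 is therefore expected to land near the three measured values, with a step from compound 3 of about a 1.4-fold lower number from compound 3 to compound 4 (0.15 log units; within the scatter), in no direction that can be trusted. Compound 4 is estimated at 1000 nM in this assay, within a range from 400 nM to 2600 nM.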

Compound 4, half-maximal inhibitory concentration: 790 nM
The estimate for compound 4 lay 1.3-fold (0.10 log units) above the measured number; the measured number falls inside the stated range.
By their numbers in this assay, from the lowest: compounds 2, 4, 1 and 3 (each within the scatter of the next).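

In this assay, placing 3-allyl-2-methoxyphenyl on a carbon with a double bond to nitrogen keeps compound 4 within the scatter of all three earlier compounds (with a 1.8-fold lower number from compound 3 to compound 4 (0.25 log units; within the scatter) and a 1.1-fold higher number from compound 2 to compound 4 (0.02 log units; within the scatter) and a 1.4-fold lower number from compound 1 to compound 4 (0.14 log units; within the scatter)). The earlier compounds had shown this only for 4-(trifluoromethyl)phenyl, 2,4-dichlorophenyl and 4-(dimethylamino)phenyl, whereas compound 4 extends the finding to an aryl group with 11 heavy atoms, an oxygen and a double bond outside aromatic rings, so that none of the four aryl groups is separated from another beyond the scatter. Nothing shown here offers a reason for this flat result.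

The allyl and methoxy groups enter together in compound 4, so what each contributes alone cannot be read from these compounds. Going by these compounds, it also remains open whether any group at this place can move the number beyond the scatter, for example an aryl group carrying a carboxylic acid, or a longer alkyl chain in place of the aryl ring.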